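Halogen swap at the para position of the shared core

The source may report more compounds than this note shows. Statements on the series, on what has been measured and on what is new or still open speak of the compounds shown alone.

Compound 2 `O=C1Nc2ccc([N+](=O)[O-])cc2/C1=N/NC(=S)Nc1ccc(F)cc1` stands lowest of the two measured compounds: in a functional assay on the whole organism for inhibition, with Lemna aequinoctialis as the target, tested at 10 ug/mL (on this read-out higher numbers stand for more inhibition of growth at the one concentration tested and lower numbers for less inhibition of growth), compound 2 gives 5%, whereas compound 1 `CCCCCCNC(=S)N/N=C1\C(=O)Nc2ccc([N+](=O)[O-])cc21` gives 25%. Among the compounds with values here, the single measured step, a number 20 percentage points lower from compound 1 to compound 2 (beyond the scatter), concerns the substituent on the amide-type nitrogen, not the halogen on the aryl ring. Compound 3 `O=C1Nc2ccc([N+](=O)[O-])cc2/C1=N/NC(=S)Nc1ccc(I)cc1` differs from compound 2 by iodo in place of fluoro on an aromatic carbon. Within the data shown here, no measured step bears on this change, so nothing beyond the scatter is expected; the estimated step is a number 5 percentage points higher from compound 2 to compound 3 (within the scatter). Compound 3 is therefore expected to give about 10% in this assay, within 0% to 30%.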

Compound 3, percent growth inhibition at one concentration: 5%
For compound 3 the middle estimate is 5 percentage points above the measured one, and the stated range covers the measured number.
By their numbers in this assay, from the lowest: compounds 2 and 3 (each within the scatter of the next); then compound 1.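

Iodo in place of fluoro on this aromatic carbon, para to a large group, gives no change at the digits printed from compound 2 to compound 3 (within the scatter) in this assay and so separates the two halogens by nothing beyond the scatter. With 4-iodophenyl in place of hexyl on the amide-type nitrogen, the result is a number 20 percentage points lower from compound 1 to compound 3 (beyond the scatter) and the drop seen with 4-fluorophenyl recurs with the heavier halogen. No evidence on the reason for either result is available here.

Still open, on these data alone, is whether an amine or a carboxylic acid at this ring position would move the number. As far as these compounds go, a chain longer than hexyl on the amide-type nitrogen also remains untested in these compounds.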